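Ester variation on a shared core: cytotoxicity working notes

A few compounds are considered here, and "the series" means these few. Any claim that something is new, unique, unknown or untested is made for them only; others in the source may bear on it.

Measured so far in an ADME assay on Vero cells (Chlorocebus sabaeus) for cytotoxicity, read by MTT assay, with a stated time of 48 h; a higher number here means a weaker inhibitor, a lower number a stronger inhibitor:
compound 1 `CCCC(=O)OC1CCC(CN2CCN(c3cc(=O)c4cc(C(F)(F)F)cc([N+](=O)[O-])c4s3)CC2)CC1` gives > 64 ug/mL, a limit of the assay.
compound 2 `O=C(OC1CCC(CN2CCN(c3cc(=O)c4cc(C(F)(F)F)cc([N+](=O)[O-])c4s3)CC2)CC1)c1ccco1` gives > 64 ug/mL, a limit of the assay.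
compound 3 `O=C(OC1CCC(CN2CCN(c3cc(=O)c4cc(C(F)(F)F)cc([N+](=O)[O-])c4s3)CC2)CC1)c1ccc2ccccc2c1` gives > 64 ug/mL, a limit of the assay.

Compound 1 stands only as a limit in this assay, and the two further values shown are limits as well. Where compound 1 carries propyl on a carbonyl carbon, compound 2 carries furan-2-yl and compound 3 naphthalen-2-yl at the same place. The step that the two limits leave unreadable from compound 1 to compound 2 cannot be sized, nor can a step that the two limits leave unreadable from compound 1 to compound 3 or a step that the two limits leave unreadable from compound 2 to compound 3, because of the limit of > 64 ug/mL in this assay, at which 3 of the 3 values shown sit. Compound 4 `O=C(OC1CCC(CN2CCN(c3cc(=O)c4cc(C(F)(F)F)cc([N+](=O)[O-])c4s3)CC2)CC1)c1ccc(C(F)(F)F)cc1` differs from compound 1 thus: 4-(trifluoromethyl)phenyl in place of propyl on a carbonyl carbon. All three measured steps bear on this change, since each replaces propyl on the same carbonyl carbon, and none of them could be read. No step beyond the scatter is therefore expected in either direction, and the step that the limit leaves unreadable from compound 1 to compound 4 is an estimate only. Compound 4 is expected to give 100 ug/mL, within 50 ug/mL to 300 ug/mL, most likely again reported as a limit.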

Compound 4, half-maximal inhibitory concentration: > 64 ug/mL
Compound 4: no number, only a limit; the forecaster's own chance of this, stated with the estimate: 85%; the middle value lies beyond the limit too.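

Within the data shown here, no step from compound 4 to compound 1, compound 2 or compound 3 can be read in this assay, because all four compounds stand at one limit: the limit of > 64 ug/mL in this assay, at which 4 of the 4 values shown sit. The compounds shown leave open whether any group on this carbonyl carbon changes the cytotoxicity of the shared core.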